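Dropping the 4-fluorophenyl from the ring nitrogen

This account rests on a few compounds, and the source may have more. Where it says the series, first, only, none or still open, it means among the compounds named here.

Compound 1 `O=C1COc2ccc(-c3cnc(Cl)c(NS(=O)(=O)c4ccc(F)cc4)c3)cc2N1c1ccc(F)cc1`: in a functional assay on A549 cells (Homo sapiens) for antiproliferative activity, read by MTT assay, with a stated time of 72 h (on this read-out lower numbers stand for stronger inhibition and higher numbers for weaker inhibition), compound 1 gives 22300 nM.
Compound 2 `O=C1COc2ccc(-c3cnc(Cl)c(NS(=O)(=O)c4ccc(F)cc4)c3)cc2N1`: in this assay compound 2 reaches only the limit of > 40000 nM.
Compound 3 `O=C1COc2ccc(-c3cnc4ccccc4c3)cc2N1c1ccc(F)cc1`: in this assay compound 3 likewise reaches only the limit of > 40000 nM.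

All three measured compounds sit at or near the weak end of this assay, and the limit of > 40000 nM in this assay, at which 2 of the 3 values shown sit, holds two of them. Among the measured compounds shown here, the single counted change, (hydrogen in place of 4-fluorophenyl on an amide-type nitrogen in a ring), gives an at least 1.7-fold higher number from compound 1 to compound 2 (0.25 log units; that floor lies within the scatter). The difference between the core of compound 1 and the core of compound 3 is not broken down here.

Compound 4 `O=C1COc2ccc(-c3cnc4ccccc4c3)cc2N1` carries the same change made on the core of compound 3, namely (hydrogen in place of 4-fluorophenyl on an amide-type nitrogen in a ring). Since compound 3 already stands at a limit in this assay, compound 4 is expected to stay there as well, so that a step that the limit leaves unreadable from compound 3 to compound 4 is the expected step, resting on the small measured step from compound 1 to compound 2 and on compound 3 being at a limit. For compound 4 the estimate in this assay is therefore 70000 nM, from 30000 nM to 200000 nM.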

Compound 4, half-maximal inhibitory concentration: > 40000 nM
Compound 4: only a limit was reported (the forecaster's own chance of this, stated with the estimate: 90%); the middle value does not contradict the limit.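

In this assay compound 3 and compound 4 both stand only at a limit, so no step can be read for hydrogen in place of 4-fluorophenyl on the core of compound 3: the limit of > 40000 nM in this assay, at which 3 of the 4 values shown sit.

The compounds shown leave open whether this change acts on the core of compound 3 as it does on the core of compound 1.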